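A few compounds are considered here, and "the series" means these few. Any claim that something is new, unique, unknown or untested is made for them only; others in the source may bear on it.

Of the compounds shown here, two that share one core have been measured in a functional assay on aorta (strain Wistar) for inhibition, with Thoracic aorta (Rattus norvegicus) as the target; a lower number here means a stronger inhibitor, a higher number a weaker inhibitor. Compound 1 `CCOc1nc(-c2cc3ccccc3o2)cc(-c2ccccc2)c1C#N` gives 310000 nM in this assay. Compound 2 `CCOc1nc(-c2cc3ccccc3o2)cc(-c2ccc(Cl)cc2)c1C#N` adds a chloro group to the structure of the first compound. In this assay compound 2 gives 221000 nM. Going by the values given here, the only measured step is a 1.4-fold lower number from compound 1 to compound 2 (0.15 log units; within the scatter), and the two numbers cannot be told apart beyond the scatter, so compound 2 stands together with compound 1 rather than apart from it.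

Compound 3 `CCOc1nc(-c2cc3ccccc3o2)cc(-c2ccc(Cl)cc2Cl)c1C#N` has not yet been measured. It differs from compound 2 by chloro in place of hydrogen on an aromatic carbon. Among the compounds with values here, the one measured step that bears on this change is a 1.4-fold lower number from compound 1 to compound 2 (0.15 log units; within the scatter), in which a first chloro group entered the same six-membered aromatic ring of carbon only and moved the number only within the scatter. A second chloro group on that ring is therefore expected to move the number little in this assay, perhaps slightly downward, with no step beyond the scatter as the central expectation. The expected step is a 1.1-fold lower number from compound 2 to compound 3 (0.04 log units; within the scatter). Compound 3 is expected to give about 200000 nM in this assay, with a range from 90000 nM to 450000 nM.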

Compound 3, half-maximal inhibitory concentration: 442000 nM
Beside the measured number, compound 3's estimate is 2.2-fold (0.34 log units) below it; the measured number falls inside the stated range.
By their numbers in this assay, from the lowest: compounds 2, 1 and 3 (each within the scatter of the next).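

In this assay, going by these compounds alone, a chloro group placed ortho to a large group and meta to a chloro group gives a 2.0-fold higher number from compound 2 to compound 3 (0.30 log units; within the scatter) and so stays within the scatter, just as the first chloro group on this ring did. Read as one change, 2,4-dichlorophenyl in place of phenyl gives a 1.4-fold higher number from compound 1 to compound 3 (0.15 log units; within the scatter) and is also within the scatter, so neither one nor two chloro groups on this ring produce a difference that can be told apart from the variation between repeated measurements. No measurement at hand offers an explanation for these small steps.

The three compounds shown carry only hydrogen or chloro on this ring, so it remains open whether a different group there, such as an amine or a carboxylic acid, would move the number beyond the scatter. As far as these compounds go, it is also open whether changes elsewhere on the shared core, such as a longer chain in place of the ethoxy group, would have a larger effect in this assay than chloro groups have on this ring.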